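A few compounds are considered here, and "the series" means these few. Any claim that something is new, unique, unknown or untested is made for them only; others in the source may bear on it.

Three compounds share one core, and for two of them a number is known in an ADME assay on L6 cells (Rattus norvegicus) for cytotoxicity, read by resazurin assay, with a stated time of 72 h; on this read-out higher numbers stand for weaker inhibition and lower numbers for stronger inhibition. Compound 1 `N/C(CC(O)c1cccc2ccccc12)=N\N=C\c1cccc(Br)c1` gives 3900 nM. Compound 3 `COc1ccc(/C=N/N=C(\N)CC(O)c2ccc3ccccc3c2)cc1` gives 69000 nM, a markedly higher number, beyond the usual scatter of this assay, so compound 1 stands at the lower of the two numbers. Compound 2 `N/C(CC(O)c1ccc2ccccc2c1)=N\N=C\c1ccco1` was also in hand, but in this assay compound 2 gives "not determined" (no result reported), so it offers no footing for comparison.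

The next step leads from compound 1 to compound 4 `N/C(CC(O)c1cccc2ccccc12)=N\N=C\c1ccc(F)cc1`. The change is small and sits at one spot: 4-fluorophenyl in place of 3-bromophenyl on a carbon with a double bond to nitrogen. Nothing else in the molecule is touched.

For the measured compounds named here, no pair of measured compounds differs in just this one place, so there is no directly comparable step to lean on. Going by the values given here, the two known numbers show only that a change at this same position can move the number widely. With a change of this size, the expected step from compound 1 to compound 4 in this assay is modest, most likely a small rise in the number, a 1.5-fold higher number from compound 1 to compound 4 (0.19 log units; within the scatter), though a step within the scatter would be no surprise. Compound 4 is therefore expected to give about 6000 nM, within a range from 2000 nM to 20000 nM.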

Compound 4, half-maximal inhibitory concentration: 19000 nM
The estimate for compound 4 lay 3.2-fold (0.50 log units) below the measured number; the range from low to high includes it.
By their numbers in this assay, from the lowest: compound 1; then compound 4; then compound 3.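

For the compounds shown here, exchanging 3-bromophenyl for 4-fluorophenyl on a carbon with a double bond to nitrogen gives a 4.9-fold higher number from compound 1 to compound 4 (0.69 log units; beyond the scatter), and this is the first reading in this assay of a change made at this place alone. Both groups have the same count of heavy atoms and the same single six-membered aromatic ring of carbon only, so a swap that leaves these counts untouched is still enough to move the number beyond the usual scatter. The swap changes both the halogen and where it sits on the ring, this single step cannot separate the two, and nothing measured here explains the rise.

A 4-bromophenyl or a 3-fluorophenyl group at this place would be needed to tell whether the number follows the halogen or its location on the ring. Also open, going by these compounds, is how a different kind of substituent on the phenyl ring, such as an amine or a carboxylic acid, would move the number in this assay.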